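The source may hold more compounds than are shown below. What is called first, only, known or untested is meant among the compounds shown, and "the series" means these compounds.

Measured compounds:
- compound 1 `COc1ncc(NC(=O)C(=O)c2cn(C(C)C)c3ccccc23)cn1` gives 171 nM
- compound 2 `CCn1cc(C(=O)C(=O)Nc2ccc(OC)nc2)c2ccccc21` gives 219 nM
- compound 3 `COc1ccc(NC(=O)C(=O)c2cn(C(C)C)c3ccccc23)nn1` gives 2270 nM

These three share one core and differ only in the group on the amide-type nitrogen or on the indole nitrogen. In a functional assay on FaDu cells (Homo sapiens) for cytotoxicity, read by MTT assay, with a stated time of 72 h (on this read-out lower numbers stand for higher toxicity in this test and higher numbers for lower toxicity in this test), compound 1 stands at the lowest of the three numbers; compound 2 lies within the scatter of it, while compound 3 is far away, with a 13-fold higher number from compound 1 to compound 3 (1.12 log units; beyond the scatter).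

Compound 4 `COc1ccc(NC(=O)C(=O)c2cn(C(C)C)c3ccccc23)cn1` has not yet been measured. It differs from compound 1 as follows: 6-methoxypyridin-3-yl in place of 2-methoxypyrimidin-5-yl on an amide-type nitrogen. Going by the values given here, the one measured step that bears on this change is the one from compound 1 to compound 3, where a different six-membered aromatic ring with two hetero atoms took the place of the same 2-methoxypyrimidin-5-yl and the number rose markedly. Compound 4 keeps one of the ring nitrogens instead of moving both, so a step of the same size is not expected; the data on the amide-side ring are otherwise thin, so the direction is uncertain.

Compound 4 is therefore expected to give 280 nM in this assay, within a range of 100 nM to 900 nM, which means an estimated step of a 1.6-fold higher number from compound 1 to compound 4 (0.21 log units; within the scatter).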

Compound 4, concentration lethal to 50% of the cells: 85 nM
For compound 4 the middle estimate is 3.3-fold (0.52 log units) above the measured one; the measured number lies below the stated range.
By their numbers in this assay, from the lowest: compounds 4, 1 and 2 (each within the scatter of the next, the first and the last beyond it); then compound 3.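

In this assay the change from 2-methoxypyrimidin-5-yl to 6-methoxypyridin-3-yl on the amide-type nitrogen gives a 2.0-fold lower number from compound 1 to compound 4 (0.30 log units; within the scatter) and so does not separate these two ring groups. The change from 6-methoxypyridazin-3-yl to 6-methoxypyridin-3-yl at the same place gives a 27-fold lower number from compound 3 to compound 4 (1.43 log units; beyond the scatter) and is large; since the ring of compound 1 also holds two hetero atoms, the count of hetero atoms alone does not account for the high number of compound 3. A second place also matters: with the 6-methoxypyridin-3-yl group held fixed, methyl in place of hydrogen on the saturated chain carbon bound to the aromatic nitrogen gives a 2.6-fold lower number from compound 2 to compound 4 (0.41 log units; beyond the scatter) and this modest step lies beyond the scatter. No measurement offered here explains any of these differences.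

The compounds shown leave open how the number would respond if an amine or a longer alkoxy chain took the place of the methoxy group on the ring. They also leave open what a longer chain, such as butyl, or a carboxylic acid at the end of a chain would do on the aromatic nitrogen.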